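Thiophen-2-yl in place of 4-nitrophenyl on the amide

The source may report more compounds than this note shows. Statements on the series, on what has been measured and on what is new or still open speak of the compounds shown alone.

In a functional assay on MKN-45 cells (Homo sapiens) for cytotoxicity (on this read-out higher numbers stand for weaker inhibition and lower numbers for stronger inhibition), the measured compounds stand as follows:
Compound 1 `COc1ccc(S(=O)(=O)N2CCc3cccc(NC(=O)c4ccc([N+](=O)[O-])cc4)c32)cc1` gives 95 nM.
Compound 2 `COc1ccc(S(=O)(=O)N2CCc3cc(Br)cc(NC(=O)c4ccco4)c32)cc1` gives 78 nM.
Compound 3 `COc1ccc(S(=O)(=O)N2CCc3cccc(NS(=O)(=O)c4ccc([N+](=O)[O-])cc4)c32)cc1` gives 933 nM.

Compound 1 holds the second highest of the three numbers. Its nearest neighbour is compound 2, whose number is within the usual scatter of that of compound 1, so no order between the two can be read. Compound 3, which carries a sulfonamide link in place of the amide, lies far beyond the scatter from compound 1 and is the weakest inhibitor of the three in this assay.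

The unmeasured compound 4 `COc1ccc(S(=O)(=O)N2CCc3cccc(NC(=O)c4cccs4)c32)cc1` is reached from compound 1 by one change:
thiophen-2-yl in place of 4-nitrophenyl on a carbonyl carbon

Among the compounds with values here, no step between measured compounds covers this change, so the expectation rests on the neighbouring numbers. Compound 2, which also carries a five-membered aromatic ring with one hetero atom on the carbonyl carbon, shows a number close to that of compound 1. The account therefore expects a step of a 1.2-fold higher number from compound 1 to compound 4 (0.06 log units; within the scatter) of no size beyond the scatter. For compound 4 the estimate in this assay is 110 nM, with a range from 40 nM to 300 nM.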

Compound 4, half-maximal inhibitory concentration: 31 nM
Estimate against measurement, compound 4: 3.5-fold (0.55 log units) above; measured number outside the range, below it.
By their numbers in this assay, from the lowest: compound 4; then compounds 2 and 1 (each within the scatter of the next); then compound 3.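

In this assay the place on the carbonyl carbon responds to the group it carries: thiophen-2-yl in place of 4-nitrophenyl gives a 3.1-fold lower number from compound 1 to compound 4 (0.49 log units; beyond the scatter) and so moves the number beyond the scatter. Within the data shown here, no earlier pair differed at this place alone, so the neighbouring numbers could not show this. The step also shows that the 9 heavy atoms and the six-membered aromatic ring of 4-nitrophenyl are not required for activity on these cells, as thiophen-2-yl with its 5 heavy atoms gives the lowest number of the compounds shown. Nothing available explains why this exchange lowers the number.

The compounds shown leave open whether the step follows from the loss of the nitro group or from the change of ring, which a plain phenyl or a 4-aminophenyl on the same carbonyl carbon would help to separate. They also leave the furan-2-yl and thiophen-2-yl groups uncompared on one core, as compound 2 differs from compound 4 in more than one place, and a furan-2-yl counterpart without the bromine would allow that reading.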